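Methyl to ethyl on the sulfonamide nitrogen

The compounds below may be only part of what the source reports. "The series", "measured", "known", "first", "only" and "open" are said of these compounds alone.

compound 1 `Cc1cc(COc2ccc(S(=O)(=O)NC3(CC(=O)NO)CN(C(=O)OC(C)C)C3)cc2)c2ccccc2n1` gives 1100000 nM
compound 2 `Cc1cc(COc2ccc(S(=O)(=O)NC3(C(=O)NO)CN(C(=O)C(C)C)C3)cc2)c2ccccc2n1` gives 17000000 nM
compound 3 `Cc1cc(COc2ccc(S(=O)(=O)N(C)C3(C(=O)NO)CN(C(=O)C(C)C)C3)cc2)c2ccccc2n1` gives 56000000 nM

In a physicochemical assay for solubility, with a stated time of 24 h, tested at 30 mg/mL (on this read-out lower numbers stand for lower solubility and higher numbers for higher solubility), compound 3 reads 56000000 nM and stands highest of the three, beyond the scatter of both others. Compound 4 `CCN(C1(C(=O)NO)CN(C(=O)C(C)C)C1)S(=O)(=O)c1ccc(OCc2cc(C)nc3ccccc23)cc1` is still unmeasured and differs from compound 3 by methyl in place of hydrogen on a saturated chain carbon bound to a sulfonamide nitrogen in one place, methyl in place of hydrogen on a saturated chain carbon bound to a sulfonamide nitrogen. Among the measured compounds shown here, the one measured step bearing on this is a 3.3-fold higher number from compound 2 to compound 3 (0.52 log units; beyond the scatter) for methyl in place of hydrogen on a sulfonamide nitrogen. That step is modest and concerns a different position, so no step beyond the scatter is expected in this assay here. The expected step is a 1.2-fold lower number from compound 3 to compound 4 (0.09 log units; within the scatter) and stays small. Compound 4 is estimated at 45000000 nM with an expected range of 17000000 nM to 60000000 nM in this read-out.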

Compound 4, solubility: 44000000 nM
The estimate for compound 4 lay 1.0-fold (0.01 log units) above the measured number, within the range that was stated.
By their numbers in this assay, from the lowest: compound 1; then compound 2; then compounds 4 and 3 (each within the scatter of the next).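

In this assay the change from methyl to ethyl on the sulfonamide nitrogen gives a 1.3-fold lower number from compound 3 to compound 4 (0.10 log units; within the scatter) and so does not separate the two compounds. Measured against the hydrogen on that nitrogen, ethyl gives a 2.6-fold higher number from compound 2 to compound 4 (0.41 log units; beyond the scatter) and thus, like methyl in a 3.3-fold higher number from compound 2 to compound 3 (0.52 log units; beyond the scatter) before it, stands beyond the scatter. No measurement shown offers a reason for these numbers.

As far as these compounds go, whether a longer chain such as propyl, or a chain ending in an amine or a carboxylic acid, would stay within the scatter of compound 4 remains open.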